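Methyl in place of chloro: notes toward compound 4

The source may hold more compounds than are shown below. What is called first, only, known or untested is meant among the compounds shown, and "the series" means these compounds.

Of the compounds shown here, three on a shared core have been measured in a functional assay on the whole organism (strain Wistar) for inhibition, with Rattus norvegicus as the target, read by paw edema, with stated times of 30 min and 1 h, at a dose of 50 mg/kg by the oral route; on this read-out higher numbers stand for more inhibition at the one dose given (going by the name of the read-out) and lower numbers for less inhibition. Compound 1 `Cc1ccc(-c2cc(N)n3nc(-c4ccc(Cl)cc4)cc3n2)cc1` gives 57.7%. Among the compounds with values here, compound 2 `Cc1ccc(-c2cc(N)n3nc(-c4ccccc4)cc3n2)cc1` gives 28.8%, and the one single-point step on record, a number 28.9 percentage points lower from compound 1 to compound 2 (beyond the scatter), is modest but beyond the scatter. Compound 3 `Nc1cc(-c2ccc(Cl)cc2)nc2cc(-c3ccc(Br)cc3)nn12` gives 13.5%, the lowest of the three numbers, beyond the scatter below compound 2 and far below compound 1.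

Compound 4 `Cc1ccc(-c2cc(N)n3nc(-c4ccc(Br)cc4)cc3n2)cc1` differs from compound 3 by methyl in place of chloro on an aromatic carbon. Within the data shown here, no measured step covers this exchange; the only step available concerns a different chloro group and a hydrogen, so it gives no direct size for a methyl entering. Compound 4 is also compound 1 with bromo in place of chloro, a pair not measured as a step: compound 1 shows 57.7% while compound 3 shows 13.5%. On that basis compound 4 is expected to sit nearer compound 1, at 42%, within 18% to 62%. The estimated step of a number 28.5 percentage points higher from compound 3 to compound 4 (beyond the scatter) is expected to be upward, beyond the scatter.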

Compound 4, a percentage reported as inhibition, in the whole organism at one dose (the size of the read-out at that dose, not a potency): 67.3%
For compound 4 the middle estimate is 25.3 percentage points below the measured one, outside the stated range (above it).
By their numbers in this assay, from the lowest: compound 3; then compound 2; then compounds 1 and 4 (each within the scatter of the next).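

In this assay, within the data shown here, methyl in place of chloro on the 4-chlorophenyl group, with bromo held constant, proves a large change, a number 53.8 percentage points higher from compound 3 to compound 4 (beyond the scatter), and gives the first direct reading at this position. With the methyl kept, bromo in place of hydrogen gives a number 38.5 percentage points higher from compound 2 to compound 4 (beyond the scatter), which points the same way as the loss seen with hydrogen in place of chloro, a number 28.9 percentage points lower from compound 1 to compound 2 (beyond the scatter), while bromo and chloro cannot be told apart, a number 9.6 percentage points higher from compound 1 to compound 4 (within the scatter). No independent data accompany these numbers to account for the size of the methyl step.

As far as these compounds go, whether an ethyl or a methoxy group in place of the methyl would keep the higher number remains open. Also open, from the compounds shown here alone, is whether the exchange of chloro for methyl has the same size when the bromo is replaced by chloro or hydrogen.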